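Swapping a benzyl substituent while cytotoxicity stays beyond the limit

The source may report more compounds than this note shows. Statements on the series, on what has been measured and on what is new or still open speak of the compounds shown alone.

Measured compounds:
- compound 1, `CN(CC1CCCCC1)N1CCN(c2nc(=O)c3cc(C(F)(F)F)cc([N+](=O)[O-])c3s2)CC1`: > 64 ug/mL
- compound 2, `O=c1nc(N2CCN(NCc3ccc(OC(F)(F)F)cc3)CC2)sc2c([N+](=O)[O-])cc(C(F)(F)F)cc12`: > 64 ug/mL
- compound 3, `O=c1nc(N2CCN(NCc3cccc(C(F)(F)F)c3)CC2)sc2c([N+](=O)[O-])cc(C(F)(F)F)cc12`: > 64 ug/mL

Of the compounds shown here, three share one core and have been tested in an ADME assay on Vero cells (Chlorocebus sabaeus) for cytotoxicity, read by MTT assay, with a stated time of 72 h; on this read-out higher numbers stand for lower toxicity in this test and lower numbers for higher toxicity in this test. Compound 1, built as `CN(CC1CCCCC1)N1CCN(c2nc(=O)c3cc(C(F)(F)F)cc([N+](=O)[O-])c3s2)CC1`, reaches only the limit of the assay, > 64 ug/mL. Compound 2, `O=c1nc(N2CCN(NCc3ccc(OC(F)(F)F)cc3)CC2)sc2c([N+](=O)[O-])cc(C(F)(F)F)cc12`, likewise stops at the limit, > 64 ug/mL. Compound 3, `O=c1nc(N2CCN(NCc3cccc(C(F)(F)F)c3)CC2)sc2c([N+](=O)[O-])cc(C(F)(F)F)cc12`, also gives no number but the limit, > 64 ug/mL. Because of the limit of > 64 ug/mL in this assay, at which 3 of the 3 values shown sit, the two steps to compound 3 cannot be sized: a step that the two limits leave unreadable from compound 1 to compound 3 and a step that the two limits leave unreadable from compound 2 to compound 3.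

Compound 4, `O=c1nc(N2CCN(NCc3ccc(Cl)cc3)CC2)sc2c([N+](=O)[O-])cc(C(F)(F)F)cc12`, has not yet been measured. It differs from compound 3 in one place: 4-chlorophenyl in place of 3-(trifluoromethyl)phenyl on a saturated chain carbon bound to an amine nitrogen. Both steps that bear on this position, from compound 1 and from compound 2, are unreadable, so no direction beyond the scatter can be read from them. The expectation for compound 4 is therefore that it, too, sits at the limit of this assay, with an estimated step that the limit leaves unreadable from compound 3 to compound 4. The estimate for compound 4 is 100 ug/mL, ranging from 64 ug/mL to 200 ug/mL.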

Compound 4, half-maximal cytotoxic concentration: > 64 ug/mL
Compound 4 ended at the assay's limit (the forecaster's own chance of this, stated with the estimate: 85%); the middle value lies beyond the limit too.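

No new step can be read from compound 4, since its comparisons with compound 1, compound 2 and compound 3 all end at the same point, because of this: the limit of > 64 ug/mL in this assay, at which 4 of the 4 values shown sit. The compounds shown leave open how far beyond that limit each one's cytotoxic concentration lies, and whether changing the benzyl substituent alters it at all.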